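A few compounds are considered here, and "the series" means these few. Any claim that something is new, unique, unknown or untested is made for them only; others in the source may bear on it.

Measured so far in a functional assay on HepG2 cells (Homo sapiens) for antiproliferative activity, read by MTT assay, with a stated time of 24 h; a lower number here means a stronger inhibitor, a higher number a weaker inhibitor:
Compound 1 `C=CCOc1ccc2c(=O)c(-c3cc(OC)c(OC)cc3OC)coc2c1` gives 3450 nM.
Compound 2 `COc1cc(OC)c(-c2coc3cc(OCc4ccccc4)ccc3c2=O)cc1OC` gives 1320 nM.
Compound 3 `COc1cc(OC)c(-c2coc3cc(OCc4ccccc4C#N)ccc3c2=O)cc1OC` gives only a limit, > 10000 nM.

Compound 1 holds the highest of the two numbers, with compound 2 nearest by a 2.6-fold lower number from compound 1 to compound 2 (0.42 log units; beyond the scatter). Compound 3 sits at the assay limit (the limit of > 10000 nM in this assay, at which 1 of the 3 values shown sits). Compound 4 `COc1cc(OC)c(-c2coc3cc(OCc4ccc(C(F)(F)F)cc4)ccc3c2=O)cc1OC` differs from compound 1 by 4-(trifluoromethyl)phenyl in place of vinyl on a saturated chain carbon bound to an oxygen on an aromatic ring. For the measured compounds named here, two measured steps bear on this: the gain a 2.6-fold lower number from compound 1 to compound 2 (0.42 log units; beyond the scatter) for phenyl in place of vinyl, and the loss an at least 7.5-fold higher number from compound 2 to compound 3 (0.87 log units; beyond the scatter) for cyano in place of hydrogen on that ring; the direct step of an at least 2.8-fold higher number from compound 1 to compound 3 (0.46 log units; beyond the scatter) likewise points to a weaker inhibitor. A substituted ring may cancel the gain of plain phenyl, so compound 4 is expected to land close to compound 1, with a wide range either way. For compound 4 the expected step is a 1.2-fold lower number from compound 1 to compound 4 (0.06 log units; within the scatter). The estimate for compound 4 is 3000 nM, from 800 nM to 12000 nM.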

Compound 4, half-maximal inhibitory concentration: 890 nM
Compound 4: middle estimate off by 3.4-fold (0.53 log units), on the high side; low and high end bracket the measured number.
By their numbers in this assay, from the lowest: compounds 4 and 2 (each within the scatter of the next); then compound 1. At a limit, above all of these: compound 3.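

In this assay, a substituted phenyl on this chain carbon keeps the gain over vinyl, with a 3.9-fold lower number from compound 1 to compound 4 (0.59 log units; beyond the scatter), so the loss seen with 2-cyanophenyl does not extend to every substituted ring. Trifluoromethyl in place of hydrogen stays within the scatter, with a 1.5-fold lower number from compound 2 to compound 4 (0.17 log units; within the scatter), while 4-(trifluoromethyl)phenyl in place of 2-cyanophenyl gives an at least 11-fold lower number from compound 3 to compound 4 (1.05 log units; beyond the scatter). That last step is a bound, since compound 3 gives only a limit: the limit of > 10000 nM in this assay, at which 1 of the 4 values shown sits.

Trifluoromethyl and nitrile differ in both identity and ring position, so the two remain unseparated. From the compounds shown here alone, whether an amine or a carboxylic acid on this ring is tolerated stays open.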